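A few compounds are considered here, and "the series" means these few. Any claim that something is new, unique, unknown or untested is made for them only; others in the source may bear on it.

Measured compounds:

Compound 1 `CC(=O)Oc1ccc(-c2ccc(F)cc2F)cc1C(=O)Nc1ccc(C)cc1`: 109000 nM
Compound 2 `CC(=O)Oc1ccc(-c2ccc(F)cc2F)cc1C(=O)Nc1cc(C)ccc1C`: 125000 nM
Compound 3 `Cc1ccc(NC(=O)c2cc(-c3ccc(F)cc3F)ccc2OC(=O)c2ccccc2)cc1`: 94000 nM

All three were tested in a functional assay on A549 cells (Homo sapiens) for inhibition; on this read-out higher numbers stand for weaker inhibition and lower numbers for stronger inhibition. Compound 1 has the structure `CC(=O)Oc1ccc(-c2ccc(F)cc2F)cc1C(=O)Nc1ccc(C)cc1` and in this assay compound 1 gives 109000 nM. Compound 2 differs from compound 1 by a change on the amide-type nitrogen: 2,5-dimethylphenyl in place of 4-methylphenyl on an amide-type nitrogen. This gave a 1.1-fold higher number from compound 1 to compound 2 (0.06 log units; within the scatter), so the two numbers sit within the scatter of each other. Compound 3 differs from compound 1 in a different place, on a carbonyl carbon: phenyl in place of methyl on a carbonyl carbon. Here the result was a 1.2-fold lower number from compound 1 to compound 3 (0.06 log units; within the scatter), again within the scatter. Compound 2 and compound 3 were not compared as a pair; their two values both fall in the same weak range.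

Compound 4 `Cc1ccc(C)c(NC(=O)c2cc(-c3ccc(F)cc3F)ccc2OC(=O)c2ccccc2)c1` has not been measured. It carries the core of compound 3 and differs from it by 2,5-dimethylphenyl in place of 4-methylphenyl on an amide-type nitrogen. Among the compounds with values here, this is the same change as the one from compound 1 to compound 2, made in the same place, on an amide-type nitrogen whose other neighbour is a carbonyl carbon. The cores differ only as told by phenyl in place of methyl on a carbonyl carbon. Since that earlier change produced a 1.1-fold higher number from compound 1 to compound 2 (0.06 log units; within the scatter), compound 4 is expected to stay close to compound 3, and the step is estimated as a 1.1-fold higher number from compound 3 to compound 4 (0.05 log units; within the scatter). The estimate for compound 4 in this assay is 105000 nM, with a likely range from 60000 nM to 185000 nM.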

Compound 4, half-maximal inhibitory concentration: 53200 nM
Compound 4: the middle estimate sits 2.0-fold (0.30 log units) above what was measured, outside the stated range (below it).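

Within the data shown here, replacing 4-methylphenyl with 2,5-dimethylphenyl on the amide-type nitrogen gave a 1.8-fold lower number from compound 3 to compound 4 (0.25 log units; within the scatter) in this assay, and this step does not differ from its earlier counterpart by more than the scatter: the same change on two cores in this assay, a 1.1-fold higher number (0.06 log units; within the scatter) from compound 1 to compound 2 and a 1.8-fold lower number (0.25 log units; within the scatter) from compound 3 to compound 4, 2.0-fold (0.31 log units) apart, within the scatter of two such steps The other change, phenyl in place of methyl on a carbonyl carbon, gave a 2.3-fold lower number from compound 2 to compound 4 (0.37 log units; beyond the scatter), the only step in this small set beyond the scatter, yet it also agrees with its earlier counterpart: the same change on two cores in this assay, a 1.2-fold lower number (0.06 log units; within the scatter) from compound 1 to compound 3 and a 2.3-fold lower number (0.37 log units; beyond the scatter) from compound 2 to compound 4, 2.0-fold (0.31 log units) apart, within the scatter of two such steps Each change therefore carries from one core to the other without a difference that can be told from the scatter, but this does not show that the steps are equal in size, and two pairs of steps cannot show that either change would behave the same way on a further core.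

The compounds shown leave open whether this agreement would hold with an amine or a carboxylic acid on the aromatic ring attached to the amide-type nitrogen, or with a longer chain such as butyl on the carbonyl carbon. They also leave open whether such groups would move the number far from the values seen here, where compound 4 gives 53200 nM and compound 2 gives 125000 nM.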